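Oxadiazole sulfonamides at the EP1 receptor: benzyl variation

The source may report more compounds than this note shows. Statements on the series, on what has been measured and on what is new or still open speak of the compounds shown alone.

Measured so far in an assay on CHO cells for displacement of a labelled ligand from prostaglandin E2 receptor EP1 subtype (Homo sapiens); on this read-out lower numbers stand for stronger inhibition and higher numbers for weaker inhibition:
compound 1 `CCc1ccccc1N(CC(=O)OCc1ccc(OC)cc1)S(=O)(=O)c1ccc(C)cc1` — 63 nM; 63.1 nM (2 entries)
compound 2 `COc1ccc(Cc2nnc(CN(c3cccc(Cl)c3C)S(=O)(=O)c3ccc(C)cc3)o2)cc1` — 6.31 nM
compound 3 `COc1ccc(Cc2nnc(CN(c3cccc(Cl)c3Cl)S(=O)(=O)c3ccc(C)cc3)o2)cc1` — 7.94 nM

Compound 2 holds the lowest number of the two single values in this assay, with compound 3 nearest; the step of a 1.3-fold higher number from compound 2 to compound 3 (0.10 log units; within the scatter) is within the scatter, so the two cannot be placed in order. Compound 1, with a different chain, is an outlier at 63 nM; 63.1 nM (2 entries); its repeat entries the several entries of compound 1 in this assay, 63 nM; 63.1 nM (2 entries) show how closely duplicate measurements of this kind agree.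

Compound 4 `Cc1ccc(S(=O)(=O)N(Cc2nnc(Cc3ccccc3Cl)o2)c2cccc(Cl)c2C)cc1` is not yet measured. It differs from compound 2 by 2-chlorophenyl in place of 4-methoxyphenyl on a saturated chain carbon bound to an aromatic carbon. Going by the values given here, no measured step touches this position: the only step recorded, from compound 2 to compound 3, concerns the aromatic carbon of the sulfonamide-bound ring and is within the scatter. The data give no direction for the change at the benzyl group, so the expectation rests on compound 2 alone, with a wide range to cover an unknown effect.

Compound 4 is expected to give 10 nM (range 3 nM to 40 nM), which would be a step of a 1.6-fold higher number from compound 2 to compound 4 (0.20 log units; within the scatter) in this assay, estimated rather than known.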

Compound 4, half-maximal inhibitory concentration: 79.4 nM
For compound 4 the middle estimate is 7.9-fold (0.90 log units) below the measured one; the whole stated range lies below it.
By their numbers in this assay, from the lowest: compounds 2 and 3 (each within the scatter of the next); then compound 4.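

Going by these compounds alone, the benzyl position is the first place where a single change moves the number beyond the scatter: going from 4-methoxybenzyl to 2-chlorobenzyl gives a 13-fold higher number from compound 2 to compound 4 (1.10 log units; beyond the scatter) in this assay. The chloro-for-methyl change, by contrast, gave a 1.3-fold higher number from compound 2 to compound 3 (0.10 log units; within the scatter), so among the compounds shown only the benzyl group has a readable effect on the number. Nothing measured here accounts for the size of the step.

From the compounds shown here alone, whether the higher number follows the loss of the 4-methoxyphenyl group's methoxy or the arrival of the chlorine stays open, as both change in one step. Going by these compounds, an unsubstituted benzyl group would bear on that question, and how an amine or a carboxylic acid on the same saturated chain carbon would read is also open.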